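The compounds below may be only part of what the source reports. "The series", "measured", "known", "first", "only" and "open" are said of these compounds alone.

Compound 3 `O=C(NCc1cn(Cc2ccc(C(F)(F)F)cc2)nn1)c1cn(-c2ccccc2)nc1-c1ccc(F)cc1` sits second highest of the three numbers in a functional assay on MCF7 cells (Homo sapiens) for antiproliferative activity, read by sulforhodamine B assay, with a stated time of 48 h (a lower number here means a stronger inhibitor of growth, a higher number a weaker inhibitor of growth), where compound 3 gives 810 nM. Compound 1 `O=C(NCc1cn(Cc2ccc(C(F)(F)F)cc2)nn1)c1cn(-c2ccccc2)nc1-c1ccccc1` gives 840 nM, and the step of a 1.0-fold lower number from compound 1 to compound 3 (0.02 log units; within the scatter) is flat. Among the compounds with values here, compound 2 `O=C(NCc1cn(Cc2ccc(Cl)cc2)nn1)c1cn(-c2ccccc2)nc1-c1ccc(F)cc1` gives 130 nM, and the step of a 6.2-fold higher number from compound 2 to compound 3 (0.79 log units; beyond the scatter) is the only change at the benzyl substituent seen so far: swapping chloro for trifluoromethyl raised the number beyond the scatter.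

Compound 4 `COc1cc(Cn2cc(CNC(=O)c3cn(-c4ccccc4)nc3-c3ccc(F)cc3)nn2)cc(OC)c1` carries 3,5-dimethoxyphenyl in place of 4-(trifluoromethyl)phenyl on a saturated chain carbon bound to an aromatic nitrogen. Within the data shown here, no measured step bears directly on 3,5-dimethoxyphenyl; the nearest guide is the step from compound 2 to compound 3, which shows that this benzyl substituent moves the number by a modest amount and that the trifluoromethyl group is the higher-number option among the two tried. Removing it for a differently substituted ring is therefore expected to give a modest lowering in this assay, a 2.0-fold lower number from compound 3 to compound 4 (0.31 log units; beyond the scatter), with wide uncertainty. Compound 4 is estimated at 400 nM, in the range 120 nM to 1400 nM.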

Compound 4, concentration for 50% growth inhibition: 2500 nM
Compound 4: the middle estimate sits 6.3-fold (0.80 log units) below what was measured; measured number outside the range, above it.
By their numbers in this assay, from the lowest: compound 2; then compounds 3 and 1 (each within the scatter of the next); then compound 4.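

Replacing the benzyl ring substituents at this saturated chain carbon bound to an aromatic nitrogen gives a 3.1-fold higher number from compound 3 to compound 4 (0.49 log units; beyond the scatter) and a 19-fold higher number from compound 2 to compound 4 (1.28 log units; beyond the scatter) in this assay. The 4-(trifluoromethyl)benzyl group of compound 3 therefore no longer marks the high end at this position, and the three benzyl groups now spread over a large range, with 3,5-dimethoxybenzyl giving the highest number of the three. No measurement on these compounds accounts for the rise.

The compounds shown do not separate the effect of having two methoxy groups from that of their placement on the ring, as no compound carries a single methoxy group. Going by these compounds, how an amine or a carboxylic acid on this benzyl ring would read in this assay also remains open.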